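A few compounds are considered here, and "the series" means these few. Any claim that something is new, unique, unknown or untested is made for them only; others in the source may bear on it.

Three compounds of one series were tested in a functional assay on T47D cells (Homo sapiens) for cytotoxicity, read by CCK-8 assay; on this read-out lower numbers stand for stronger inhibition and higher numbers for weaker inhibition. Compound 1 `Oc1ccccc1-c1cc(-c2ccsc2)cc(-c2ccccc2O)n1` carries a thiophen-3-yl group on the shared core, and in this assay compound 1 gives only a limit, > 50000 nM. Compound 2 `Oc1cccc(-c2cc(-c3ccsc3)cc(-c3ccccc3O)n2)c1` differs from compound 1 by 3-hydroxyphenyl in place of 2-hydroxyphenyl on an aromatic carbon, and in this assay compound 2 likewise gives only a limit, > 50000 nM. The step that the two limits leave unreadable from compound 1 to compound 2 therefore has no size that can be read. Compound 3 `Oc1ccccc1-c1cc(-c2cccnc2)cc(-c2ccccc2O)n1` differs from compound 1 by pyridin-3-yl in place of thiophen-3-yl on an aromatic carbon, and in this assay compound 3 also gives only a limit, > 50000 nM. The step that the two limits leave unreadable from compound 1 to compound 3 is equally unreadable because of the limit of > 50000 nM in this assay, at which 3 of the 3 values shown sit.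

Compound 4 `Oc1cccc(-c2cc(-c3cccnc3)cc(-c3ccccc3O)n2)c1` has not been measured in this assay. Among the compounds with values here, it differs from compound 3 by 3-hydroxyphenyl in place of 2-hydroxyphenyl on an aromatic carbon, which is the same kind of change as the one from compound 1 to compound 2; the surroundings of the place differ, being meta to a pyridin-3-yl group in one case and meta to a thiophen-3-yl group in the other. Because the earlier step that the two limits leave unreadable from compound 1 to compound 2 could not be sized, it offers no number to carry over. Because compound 3 gives only a limit > 50000 nM, the step to compound 4 is expected to be a step that the limit leaves unreadable from compound 3 to compound 4. Compound 4 is therefore expected to give 80000 nM, with the estimate spanning 30000 nM to 300000 nM.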

Compound 4, half-maximal inhibitory concentration: 6230 nM
Compound 4: middle estimate off by 13-fold (1.11 log units), on the high side; the whole stated range lies above it.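

In this assay, 3-hydroxyphenyl in place of 2-hydroxyphenyl, with a pyridin-3-yl group on the shared core, gives an at least 8.0-fold lower number from compound 3 to compound 4 (0.90 log units; beyond the scatter), and pyridin-3-yl in place of thiophen-3-yl, with the 3-hydroxyphenyl group present, gives an at least 8.0-fold lower number from compound 2 to compound 4 (0.90 log units; beyond the scatter). As far as these compounds go, this shows that the change can produce a readable gain on the core of compound 3, and that the gain there depends on the pyridin-3-yl group being present, since the same change on the core of compound 1 leads only to compound 2, which stays at a limit; both sizes are lower bounds, so the real gain on the core of compound 3 remains unknown. It does not show that the change has no effect on the core of compound 1, nor how the two cores compare in size of effect, because the earlier steps cannot be read: the limit of > 50000 nM in this assay, at which 3 of the 4 values shown sit.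

Only compound 4 gives a number, so the compounds shown leave open how the activity responds to other groups in the place of the pyridin-3-yl group, such as an amine or a longer alkyl chain. They also leave open whether a carboxylic acid in place of the hydroxyl group of the 3-hydroxyphenyl group would keep a measurable value.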